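This account rests on a few compounds, and the source may have more. Where it says the series, first, only, none or still open, it means among the compounds named here.

Measured so far:
compound 1, `O=C(NC(=S)NNc1ncnc2ccccc12)c1ccc(C(F)(F)F)cc1`: 7920 nM
compound 2, `COc1cc2ncnc(NNC(=S)NC(=O)c3ccc(F)cc3)c2cc1OC`: 4530 nM
compound 3, `COc1cc2ncnc(NNC(=S)NC(=O)c3ccc(C)cc3)c2cc1OC`: 24200 nM

In a functional assay on KB cells (Homo sapiens) for cytotoxicity, read by MTT assay, with a stated time of 72 h (a lower number here means a stronger inhibitor, a higher number a weaker inhibitor), compound 1 stands second highest of the three numbers; compound 2 lies within the scatter of it, while compound 3 sits beyond the scatter. Compound 4, `O=C(NC(=S)NNc1ncnc2ccccc12)c1ccccc1`, differs from compound 1 by hydrogen in place of trifluoromethyl on an aromatic carbon. Within the data shown here, the single measured step that touches the same ring, a 5.3-fold higher number from compound 2 to compound 3 (0.73 log units; beyond the scatter), was modest and concerned another pair of groups on a different core, so it bears on the present change only loosely. A step no larger than that one is therefore expected, with no sure direction. Compound 4 is expected to give 9000 nM, between 3500 nM and 24000 nM. The expected step is a 1.1-fold higher number from compound 1 to compound 4 (0.06 log units; within the scatter).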

Compound 4, half-maximal inhibitory concentration: 2330 nM
Beside the measured number, compound 4's estimate is 3.9-fold (0.59 log units) above it, outside the stated range (below it).
By their numbers in this assay, from the lowest: compounds 4, 2 and 1 (each within the scatter of the next, the first and the last beyond it); then compound 3.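

In this assay the number falls with hydrogen in place of trifluoromethyl on the aromatic carbon, with a 3.4-fold lower number from compound 1 to compound 4 (0.53 log units; beyond the scatter) on the shared core, so this position is sensitive to the change and the trifluoromethyl is not needed for the activity seen. Among these compounds, the earlier step, a 5.3-fold higher number from compound 2 to compound 3 (0.73 log units; beyond the scatter), compared only two substituents on another core and gave no reading against hydrogen. No measurement here accounts for the step. Still open, going by these compounds, is how an amine or a carboxylic acid at this place would read, and whether hydrogen would give a similar step on the core of compound 2.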